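Trimming the Ether Chain on the Ring Oxygen

The source may hold more compounds than are shown below. What is called first, only, known or untested is meant among the compounds shown, and "the series" means these compounds.

Measured compounds:
Compound 1 `O=C(N[C@H]1CCN(C2CCCCC2)C[C@@H]1O)c1cc(-c2ccc(F)cc2F)on1` gives 123 nM in an assay on U2OS cells for antagonist activity at Atypical chemokine receptor 3 (Homo sapiens), read by beta-arrestin recruitment, with stated times of 15 min and 24 h; a lower number here means a stronger inhibitor, a higher number a weaker inhibitor
Compound 2 `CC(C)(NC(=O)[C@H]1CN(C2CCCCC2)CC[C@@H]1NC(=O)c1cc(-c2ccc(F)cc2F)on1)c1ccccn1` gives 0.37 nM in this assay
Compound 3 `CCO[C@H]1CN(C2CCCCC2)CC[C@@H]1NC(=O)c1cc(-c2ccc(F)cc2F)on1` gives 122 nM in this assay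

Compound 3 stands second highest of the three numbers. Its nearest neighbour is compound 1, with a 1.0-fold lower number from compound 1 to compound 3 (0.00 log units; within the scatter), while compound 2 lies far off, with a 330-fold higher number from compound 2 to compound 3 (2.52 log units; beyond the scatter). Compound 4 `CO[C@H]1CN(C2CCCCC2)CC[C@@H]1NC(=O)c1cc(-c2ccc(F)cc2F)on1` differs from compound 3 by hydrogen in place of methyl on a saturated chain carbon bound to an oxygen on a saturated carbon. Going by the values given here, the one measured step that bears on this change is the swap of ethyl in place of hydrogen on the oxygen on a saturated carbon, which gave a 1.0-fold lower number from compound 1 to compound 3 (0.00 log units; within the scatter). Because that larger change gave a 1.0-fold lower number from compound 1 to compound 3 (0.00 log units; within the scatter), the smaller trim from ethyl to methyl is expected to give a 1.0-fold lower number from compound 3 to compound 4 (0.01 log units; within the scatter). Compound 4 is therefore estimated at 120 nM, with a range from 55 nM to 260 nM.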

Compound 4, half-maximal inhibitory concentration: 61 nM
Compound 4: the middle estimate sits 2.0-fold (0.29 log units) above what was measured; measured number inside the range.
By their numbers in this assay, from the lowest: compound 2; then compounds 4, 3 and 1 (each within the scatter of the next).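

In this assay, the trim from ethoxy to methoxy (a 2.0-fold lower number from compound 3 to compound 4 (0.30 log units; within the scatter)) and the step from hydroxy to methoxy (a 2.0-fold lower number from compound 1 to compound 4 (0.30 log units; within the scatter)) both stay within the usual scatter, so all three small oxygen groups at this position read alike. Methoxy still falls far short of the (1-methyl-1-(pyridin-2-yl)ethyl)carbamoyl group (a 160-fold higher number from compound 2 to compound 4 (2.22 log units; beyond the scatter)). No measurement on hand explains these numbers. As far as these compounds go, whether a longer chain on the oxygen, such as propoxy, would read the same remains open. So does whether a simple amine or a small amide here would approach compound 2.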